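The source may hold more compounds than are shown below. What is called first, only, known or untested is meant among the compounds shown, and "the series" means these compounds.

Three compounds share one core and are compared in an assay on Cerebral cortex for displacement of a labelled ligand from adenosine receptor A1 (Bos taurus); a lower number here means a stronger inhibitor, a higher number a weaker inhibitor. In that assay compound 1 `CNc1nc(-c2ccccc2)nc2c1nnn2Cc1ccccc1F` gives 25 nM, and compound 2 `CCNc1nc(-c2ccccc2)nc2c1nnn2Cc1ccccc1F` gives 11 nM. Compound 3 `CCCNc1nc(-c2ccccc2)nc2c1nnn2Cc1ccccc1` gives 37 nM in this assay, the highest of the three numbers: its gap to compound 1 lies within the scatter, while its gap to compound 2 lies beyond it. Among the compounds with values here, the only single-point step known is a 2.3-fold lower number from compound 1 to compound 2 (0.36 log units; beyond the scatter), and it concerns the saturated chain on the ring nitrogen rather than the benzyl group. Compound 4 `CCCNc1nc(-c2ccccc2)nc2c1nnn2Cc1ccccc1F` differs from compound 3 by fluoro in place of hydrogen on an aromatic carbon. Within the data shown here, no measured pair isolates this change, so no step beyond the scatter is expected in this assay, with only a slight lean toward a lower number, an expected 1.5-fold lower number from compound 3 to compound 4 (0.17 log units; within the scatter). Compound 4 is therefore estimated at 25 nM, with a range from 10 nM to 70 nM.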

Compound 4, inhibition constant: 3.2 nM
Estimate against measurement, compound 4: 7.8-fold (0.89 log units) above; measured number below the stated range.
By their numbers in this assay, from the lowest: compound 4; then compound 2; then compounds 1 and 3 (each within the scatter of the next).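

In this assay, within the data shown here, the change from benzyl to 2-fluorobenzyl gives a 12-fold lower number from compound 3 to compound 4 (1.06 log units; beyond the scatter), the first pair to isolate fluoro at this position, and the step is large. With the 2-fluorobenzyl group held constant, methyl in place of hydrogen further along the chain gives a 3.4-fold lower number from compound 2 to compound 4 (0.54 log units; beyond the scatter), while ethyl in place of hydrogen on the chain carbon bound to the nitrogen gives a 7.8-fold lower number from compound 1 to compound 4 (0.89 log units; beyond the scatter). The number therefore falls across these three compounds as the chain grows. Nothing available explains the size of the fluoro step. Going by these compounds, whether chloro, methoxy or trifluoromethyl would act like fluoro at this position remains open.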